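The compounds below may be only part of what the source reports. "The series", "measured", "known", "first", "only" and "open" are said of these compounds alone.

Compound 1 `O=C(O)CCNC(=O)c1ccc(CN(c2ccc(Cl)cc2)c2nc(-c3ccc(C(F)(F)F)cc3)cs2)cc1` gives 649 nM in an in vitro assay on BHK cells for displacement of a labelled ligand from gastric inhibitory polypeptide receptor (Homo sapiens), read by scintillation proximity assay (on this read-out lower numbers stand for stronger inhibition and higher numbers for weaker inhibition), the lowest of the three numbers, though neither compound 2 `O=C(O)CCNC(=O)c1ccc(CN(c2ccc(OC(F)(F)F)cc2)c2nc(-c3ccc(C(F)(F)F)cc3)cs2)cc1` at 833 nM nor compound 3 `O=C(O)CCNC(=O)c1ccc(CN(c2ccc(SC(F)(F)F)cc2)c2nc(-c3ccc(C(F)(F)F)cc3)cs2)cc1` at 777 nM is separated from it beyond the scatter. Compound 4 `O=C(O)CCNC(=O)c1ccc(CN(c2ccc(Cl)cc2)c2nc(-c3ccc(OC(F)(F)F)cc3)cs2)cc1` differs from compound 1 by trifluoromethoxy in place of trifluoromethyl on an aromatic carbon. Going by the values given here, no measured step alters this ring; the nearest comparisons are substituent swaps on the other aromatic ring of the shared core, a 1.3-fold higher number from compound 1 to compound 2 (0.11 log units; within the scatter), a 1.2-fold higher number from compound 1 to compound 3 (0.08 log units; within the scatter) and a 1.1-fold lower number from compound 2 to compound 3 (0.03 log units; within the scatter), all within the scatter. On that basis the step of a 1.1-fold higher number from compound 1 to compound 4 (0.03 log units; within the scatter) is expected to stay within the scatter, with no clear direction. Compound 4 is therefore estimated at 700 nM, in the range 300 nM to 1600 nM.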

Compound 4, half-maximal inhibitory concentration: 869 nM
For compound 4 the middle estimate is 1.2-fold (0.09 log units) below the measured one; the range from low to high includes it.
By their numbers in this assay, from the lowest: compounds 1, 3, 2 and 4 (each within the scatter of the next).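

Going by these compounds alone, the first change on this ring, 4-(trifluoromethyl)phenyl to 4-(trifluoromethoxy)phenyl, gives a 1.3-fold higher number from compound 1 to compound 4 (0.13 log units; within the scatter) in this assay. This position therefore accepts trifluoromethoxy in place of trifluoromethyl without a readable change, matching the swaps on the other aromatic ring in staying within the scatter. No available evidence bears on this result. Both groups compared here contain fluorine, so the compounds shown leave open whether an amine or a carboxylic acid on this ring would move the number beyond the scatter.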